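The compounds below may be only part of what the source reports. "The series", "measured", "known", "first", "only" and "open" are said of these compounds alone.

Measured so far:
Compound 1, `CC(C)CCOc1ccccc1C1CC(=O)c2ccccc2O1`: 47.6%
Compound 2, `CC(C)c1ccc(COc2ccccc2C2CC(=O)c3ccccc3O2)cc1`: 91.5%

In a functional assay on RAW264.7 cells (Mus musculus) for inhibition, read by immunoassay, with a stated time of 12 h, tested at 30 uM (on this read-out lower numbers stand for less inhibition and higher numbers for more inhibition at the one concentration tested (going by the name of the read-out)), compound 1 gives 47.6%, and compound 2 gives 91.5%. Compound 2 thus stands highest of the two numbers; its nearest neighbour is compound 1, and the gap between them is a number 43.9 percentage points higher from compound 1 to compound 2 (beyond the scatter). Compound 3, `CC(C)=CCOc1ccccc1C1CC(=O)c2ccccc2O1`, has not yet been measured. It differs from compound 2 in one place: 2-methylprop-1-en-1-yl in place of 4-isopropylphenyl on a saturated chain carbon bound to an oxygen on an aromatic ring. Going by the values given here, the group that enters is a short chain with no ring and one double bond outside aromatic rings, so the change is roughly the reverse of the one measured step. Among the compounds with values here, the only step that bears on it is a number 43.9 percentage points higher from compound 1 to compound 2 (beyond the scatter), where a ring replaced a small saturated chain and the number rose by a large margin. Putting a small chain back in place of the ring is therefore expected to move the number the opposite way, by a step beyond the scatter, so that compound 3 lands nearer compound 1 than compound 2; how a chain with a double bond compares with a saturated chain is not shown by any measured pair. The estimated change is a number 36.5 percentage points lower from compound 2 to compound 3 (beyond the scatter). Compound 3 is estimated at 55%, with a range from 30% to 80%.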

Compound 3, a percentage reported as inhibition, at one concentration (the size of the read-out at that concentration, not a potency): 41.8%
The estimate for compound 3 lay 13.2 percentage points above the measured number, within the range that was stated.
By their numbers in this assay, from the lowest: compounds 3 and 1 (each within the scatter of the next); then compound 2.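

In this assay, putting 2-methylprop-1-en-1-yl in place of 4-isopropylphenyl on a saturated chain carbon bound to an oxygen on an aromatic ring gives a number 49.7 percentage points lower from compound 2 to compound 3 (beyond the scatter), so the large gap seen with isobutyl also appears with a second short chain. Comparing the two short chains directly gives a number 5.8 percentage points lower from compound 1 to compound 3 (within the scatter), so the double bond in 2-methylprop-1-en-1-yl, which isobutyl lacks, cannot be told apart from the saturated chain on this read-out. Among these three compounds, the two chains with no ring therefore sit together and the group with the aromatic ring stands apart, but nothing available here gives a reason for this pattern.

Going by these compounds, it remains open whether the high number of compound 2 belongs to the aromatic ring itself or to the isopropyl group it carries, and whether a plain phenyl, a cyclohexyl ring or a longer chain such as octyl would keep that number. Each number also comes from a single concentration, so these compounds give a size of effect at that concentration and leave their potency unknown.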